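Dichlorophenyl Ethenyl Analogue: Expected Cytotoxicity Near Limit

The source may report more compounds than this note shows. Statements on the series, on what has been measured and on what is new or still open speak of the compounds shown alone.

Compound 1 `O=C(/C=C\c1cccc(Cl)c1)N1N=C(c2ccncc2)OC1c1c[nH]c2ccccc12`: in an ADME assay on HeLa cells (Homo sapiens) for cytotoxicity, read by MTT assay, with a stated time of 72 h (a lower number here means a stronger inhibitor of growth, a higher number a weaker inhibitor of growth), compound 1 gives > 30 ug/mL, which is a limit of the assay.
Compound 2 `O=C(/C=C\c1ccc(Cl)cc1)N1N=C(c2ccncc2)OC1c1c[nH]c2ccccc12`: in this assay compound 2 gives > 30 ug/mL, also a limit.

Among the compounds with values here, compound 2 thus stands at the assay limit, as does compound 1, so the step that the two limits leave unreadable from compound 1 to compound 2 cannot be read; the only evidence is the limit of > 30 ug/mL in this assay, at which 2 of the 2 values shown sit. Compound 3 `O=C(/C=C/c1c(Cl)cccc1Cl)N1N=C(c2ccncc2)OC1c1c[nH]c2ccccc12` carries the change (2-(2,6-dichlorophenyl)ethenyl in place of 2-(4-chlorophenyl)ethenyl on a carbonyl carbon). Within the data shown here, no measured step is readable, so no step beyond the scatter is foreseen, and compound 3 is expected to remain at or near the limit. Compound 3 is therefore estimated at 40 ug/mL, within 15 ug/mL to 100 ug/mL. The expected step is a step that the limit leaves unreadable from compound 2 to compound 3.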

Compound 3, concentration for 50% growth inhibition: > 30 ug/mL
Compound 3 gave a limit, no number; the forecaster's own chance of this, stated with the estimate: 75%; the middle value is on the limit's open side.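

The steps among compound 1, compound 2 and compound 3 cannot be read, since all three stand at a limit: the limit of > 30 ug/mL in this assay, at which 3 of the 3 values shown sit.

The compounds shown leave open whether the chlorine pattern on the phenyl ring changes growth inhibition in this assay.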